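The compounds below may be only part of what the source reports. "The series", "measured", "known", "first", "only" and "open" are said of these compounds alone.

Working notes on the series.

Among the compounds with values here, the only number so far in an ADME assay on L1210/0 cells (Mus musculus) for cytotoxicity, with a stated time of 48 h (a lower number here means a stronger inhibitor, a higher number a weaker inhibitor), belongs to compound 1, `C=Cc1cn([C@H]2C[C@H](O)[C@@H](CO)O2)c(=O)[nH]c1=O`: in this assay compound 1 gives 14200 nM. Compound 2, `O=c1ccn([C@@H]2C[C@H](CO)C[C@@H]2CO)c(=O)[nH]1`, sits at a limit of this assay rather than at a number; in this assay compound 2 gives > 200000 nM, which is the limit of > 200000 nM in this assay, at which 1 of the 2 values shown sits. Within the data shown here, no pair of measured compounds differs in one place, so no measured step is available to scale the change ahead, and the values of compound 1 and compound 2 are only two separate readings.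

The next compound is compound 3, `CC(C)(C)C#Cc1cn([C@H]2C[C@H](O)[C@@H](CO)O2)c(=O)[nH]c1=O`. Relative to compound 1 it carries 3,3-dimethylbut-1-yn-1-yl in place of vinyl on an aromatic carbon. Among the measured compounds shown here, nothing measured here speaks to the size or direction of such a change, so the expectation for the step from compound 1 to compound 3 in this assay is that it stays small, a 2.1-fold higher number from compound 1 to compound 3 (0.32 log units; beyond the scatter), with a lean toward a weaker number because the only anchor is compound 1 at 14200 nM. Compound 3 is therefore estimated at 30000 nM, within 6000 nM to 150000 nM.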

Compound 3, half-maximal inhibitory concentration: > 200000 nM
Compound 3: a limit, no number; the forecaster's own chance of this, stated with the estimate: 20%; at least 6.6-fold (0.82 log units) between middle value and limit.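

Within the data shown here, this is the first measured step, and it shows that the aromatic carbon two atoms from the ring nitrogen does not tolerate every carbon substituent equally: 3,3-dimethylbut-1-yn-1-yl in place of vinyl gives an at least 14-fold higher number from compound 1 to compound 3 (1.14 log units; beyond the scatter). In this assay compound 3 gives > 200000 nM, which is a limit and not a number, so the step has a lower bound and no measured end. With a second compound now at the same limit, the top of the scale in this assay no longer tells such compounds apart: the limit of > 200000 nM in this assay, at which 2 of the 3 values shown sit.

The single step swaps a double bond for a triple bond and also lengthens and branches the substituent, and the compounds shown leave open which of these changes carries the shift. Also open, going by these compounds, is how an ethynyl group, a plain propyl chain or a bromine atom on the same aromatic carbon would read against the value of compound 1, and whether any substituent there gives a lower number than vinyl.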